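Cytotoxicity notes: methyl for oxolan-3-yl on oxygen

A few compounds are considered here, and "the series" means these few. Any claim that something is new, unique, unknown or untested is made for them only; others in the source may bear on it.

In a functional assay on HepG2 cells (Homo sapiens) for cytotoxicity, read by MTT assay, with a stated time of 72 h (on this read-out higher numbers stand for weaker inhibition and lower numbers for stronger inhibition), compound 1 `O=C(N/N=C/c1ccc(O)c(Br)c1)Nc1cc2c(Nc3ccc(F)c(Cl)c3)ncnc2cc1O[C@H]1CCOC1` gives 660 nM as its number. Compound 2 `CC(C)(C)c1cc(/C=N/NC(=O)Nc2cc3c(Nc4ccc(F)c(Cl)c4)ncnc3cc2O[C@H]2CCOC2)cc(C(C)(C)C)c1O` gives 12500 nM and holds the second highest of the three numbers. Compound 3 `COc1cc2ncnc(Nc3ccc(F)c(Cl)c3)c2cc1NC(=O)N/N=C/c1cc(OC)c(OC)c(OC)c1` gives 30100 nM and is the nearest to compound 2, with a higher number beyond the scatter. Compound 1 is the furthest from compound 2, with a lower number, also beyond the scatter.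

Compound 4 `COc1cc2ncnc(Nc3ccc(F)c(Cl)c3)c2cc1NC(=O)N/N=C/c1cc(C(C)(C)C)c(O)c(C(C)(C)C)c1` follows from compound 2 by one change (methyl in place of oxolan-3-yl on an oxygen on an aromatic ring): methyl in place of oxolan-3-yl on an oxygen on an aromatic ring, which also reads as (oxolan-3-yl)oxy to methoxy.

Among the measured compounds shown here, no measured pair shows this change alone. Compound 1 and compound 2 both carry oxolan-3-yl and still stand furthest apart, so that group alone does not fix the number. For the measured compounds named here, compound 4 differs from compound 3 elsewhere as well, yet compound 3 with its methoxy gives 30100 nM as the only guide to that group. The estimate is a 1.4-fold higher number from compound 2 to compound 4 (0.13 log units; within the scatter) and is expected to stay within the scatter, with a slight lean to a higher number. For compound 4 the estimated value in this assay is 17000 nM with an expected range from 6000 nM to 45000 nM for the coming measurement.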

Compound 4, half-maximal inhibitory concentration: 26800 nM
Compound 4: the middle estimate sits 1.6-fold (0.20 log units) below what was measured, within the range that was stated.
By their numbers in this assay, from the lowest: compound 1; then compound 2; then compounds 4 and 3 (each within the scatter of the next).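

Among the compounds shown here, this is the first single-change reading: in this assay, with everything else held as in compound 2, methyl in place of oxolan-3-yl on an oxygen on an aromatic ring gives a 2.1-fold higher number from compound 2 to compound 4 (0.33 log units; beyond the scatter). The step is modest but beyond the scatter, so the group on this oxygen has a readable influence on the number, and the change to methoxy moves it towards weaker inhibition on this read-out. Nothing available explains the step, and it cannot assign the shift to the loss of the ring, its oxygen or its defined stereocentre.

Still open, going by these compounds, is whether the same change gives a step of similar size and direction with the other end of the molecule found in compound 1, since this single pair carries only the end shared by compound 2 and compound 4. Also open, on these data alone, is how this oxygen responds to groups outside the two seen here, such as a longer chain ending in an amine or in a carboxylic acid.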